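The source may report more compounds than this note shows. Statements on the series, on what has been measured and on what is new or still open speak of the compounds shown alone.

Of the compounds shown here, three have been measured in an assay on isolated protein for inhibition of Indoleamine 2,3-dioxygenase 1 (Homo sapiens), with a stated time of 60 min, tested at 10 uM; on this read-out lower numbers stand for less inhibition and higher numbers for more inhibition at the one concentration tested (going by the name of the read-out). Compound 1 `Clc1ccc2sc(SCc3ccccc3CCc3ccccc3)nc2c1` gives 9% in this assay. Compound 2 `Clc1ccc2[nH]c(SCc3ccccc3C#Cc3ccccc3)nc2c1` gives 52% in this assay. Compound 3 `c1ccc(CCc2ccccc2CSc2nc3ccccc3[nH]2)cc1` gives 43% in this assay. On these numbers compound 2 stands highest of the three, but its gap to compound 3 lies within the usual scatter of repeated measurements, so the two cannot be told apart, while its gap to compound 1 lies beyond the scatter. No pair of these compounds differs in a single place, so no step between them can be read off.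

Compound 4 `Clc1ccc2[nH]c(SCc3ccccc3/C=C/c3ccccc3)nc2c1` has not yet been measured. It differs from compound 2 in one place: 2-phenylethenyl in place of 2-phenylethynyl on an aromatic carbon. The 1 triple bond outside aromatic rings of compound 2 becomes 1 double bond outside aromatic rings in compound 4, with the same count of heavy atoms and the same ring. Since the smaller steps among the measured compounds stay within the scatter, the step from compound 2 to compound 4 is expected to be small, a number 7 percentage points lower from compound 2 to compound 4 (within the scatter), and to stay within the scatter, perhaps slightly downward. Compound 4 is therefore expected to give about 45% in this assay, with a likely range from 25% to 65%.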

Compound 4, a percentage reported as inhibition, at one concentration (the size of the read-out at that concentration, not a potency): -6%
Compound 4: middle estimate off by 51 percentage points, on the high side, outside the stated range (below it).
By their numbers in this assay, from the lowest: compound 4; then compound 1; then compounds 3 and 2 (each within the scatter of the next).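

In this assay, changing 2-phenylethynyl to 2-phenylethenyl on this aromatic carbon gives a number 58 percentage points lower from compound 2 to compound 4 (beyond the scatter). Among these compounds, this is the first change in a single place, and it shows that the result at this position can shift sharply even when the heavy-atom count and the ring stay the same and only a triple bond outside aromatic rings becomes a double bond. Nothing available explains why this change has such a large effect.

The compounds shown leave open whether a plain ethynyl group, without its phenyl ring, would behave more like the 2-phenylethynyl group of compound 2 or the 2-phenylethenyl group of compound 4. They also leave open how an amine or a carboxylic acid on that phenyl ring would read in this assay.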